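The compounds below may be only part of what the source reports. "The series", "measured", "known", "first", "only" and "open" are said of these compounds alone.

Measured compounds in a functional assay on HeLa cells (Homo sapiens) for inhibition, read by MTT assay, with a stated time of 72 h; a lower number here means a stronger inhibitor, a higher number a weaker inhibitor:
- compound 1, `COc1cc(NC(C)CCCNC(=O)Nc2ccc(Br)cc2)c2ncccc2c1`: 20000 nM
- compound 2, `COc1cc(NC(C)CCCNC(=O)NNC(=O)Nc2ccc(Cl)cc2)c2ncccc2c1`: 120000 nM
- compound 3, `COc1cc(NC(C)CCCNC(=O)NNC(=O)Nc2cccc(F)c2)c2ncccc2c1`: for compound 3 this assay reports only a limit, > 250000 nM

Compound 1 gives the lowest of the two numbers shown in this assay; the nearest number is that of compound 2, with a 6.0-fold higher number from compound 1 to compound 2 (0.78 log units; beyond the scatter). The step of an at least 12-fold higher number from compound 1 to compound 3 (1.09 log units; beyond the scatter) runs to a value that is only a limit (the limit of > 250000 nM in this assay, at which 1 of the 3 values shown sits), and an at least 2.0-fold higher number from compound 2 to compound 3 (0.31 log units; beyond the scatter) likewise ends at that limit.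

Compound 4, `COc1cc(NC(C)CCCNC(=O)Nc2ccc(C(F)(F)F)cc2)c2ncccc2c1`, is not yet measured in this assay. It differs from compound 1 in one place: trifluoromethyl in place of bromo on an aromatic carbon. Among the measured compounds shown here, none of the measured steps tests this change on its own; each of them inserts a carbamoylamino linker and alters the aryl substituent at the same time, so they bear on it only loosely. The step of an at least 2.0-fold higher number from compound 2 to compound 3 (0.31 log units; beyond the scatter) shows that a change of the aryl substituent alone can move the number at least modestly, but its direction for trifluoromethyl in place of bromo is not fixed by anything measured. The expected step is therefore no change at the digits printed from compound 1 to compound 4 (within the scatter), with the change in either direction within or near the scatter. Compound 4 is thus estimated at 20000 nM in this assay, expected between 7000 nM and 60000 nM.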

Compound 4, half-maximal inhibitory concentration: 8300 nM
For compound 4 the middle estimate is 2.4-fold (0.38 log units) above the measured one; low and high end bracket the measured number.
By their numbers in this assay, from the lowest: compound 4; then compound 1; then compound 2. At a limit, above all of these: compound 3.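

In this assay, among the compounds shown here, a 2.4-fold lower number from compound 1 to compound 4 (0.38 log units; beyond the scatter) is the first step that changes only this aromatic carbon, with trifluoromethyl in place of bromo and the linker of compound 1 kept, so this position alone can move the number beyond the scatter. Against the longer carbamoylamino linker, a 14-fold lower number from compound 2 to compound 4 (1.16 log units; beyond the scatter), but that step changes the linker and the aryl substituent together. The value of compound 3 is a limit, so an at least 30-fold lower number from compound 3 to compound 4 (1.47 log units; beyond the scatter) gives only a bound: the limit of > 250000 nM in this assay, at which 1 of the 4 values shown sits.

Going by these compounds, whether a nitrile, a methyl or a carboxylic acid at this aromatic carbon would follow trifluoromethyl or bromo remains open. Also open, on these data alone, is whether the order of bromo and trifluoromethyl would hold with the carbamoylamino linker in place.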